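Chloro on the pendant phenyl: notes toward compound 4

The compounds below may be only part of what the source reports. "The series", "measured", "known", "first", "only" and "open" are said of these compounds alone.

All numbers come from a functional assay on A549 cells (Homo sapiens) for cytotoxicity, read by MTT assay, with a stated time of 96 h; a lower number here means a stronger inhibitor, a higher number a weaker inhibitor.

compound 1 `O=C(N/N=C/c1ccccc1O)c1cc(-c2ccc(Cl)cc2)nn1Cc1ccc(Cl)nc1` — 3680 nM
compound 2 `O=C(N/N=C/c1ccccc1O)c1cc(-c2ccccc2)nn1Cc1ccccc1` — 10800 nM
compound 3 `CC(C)(C)c1ccc(Cn2nc(-c3ccccc3)cc2C(=O)N/N=C/c2ccccc2O)cc1` — 6240 nM

Compound 3 stands second highest of the three numbers; both compound 1 and compound 2 lie within the scatter of it, so no order among the three can be read. Compound 4 `CC(C)(C)c1ccc(Cn2nc(-c3ccc(Cl)cc3)cc2C(=O)N/N=C/c2ccccc2O)cc1` differs from compound 3 in one place: chloro in place of hydrogen on an aromatic carbon. Among the compounds with values here, no measured step isolates this change. Within the data shown here, the one single step available, a 1.7-fold lower number from compound 2 to compound 3 (0.24 log units; within the scatter), concerns the tert-butyl on the benzyl ring, not the chloro, and stays within the scatter. Compound 1 carries the same chloro on that phenyl but also a different benzyl arm, so next to compound 2 it shows two changes at once; compound 1 gives 3680 nM and compound 2 gives 10800 nM, a gap that cannot be assigned to either change alone. The expected step is therefore a 1.4-fold lower number from compound 3 to compound 4 (0.14 log units; within the scatter), no larger than the scatter, leaning toward a lower number. Compound 4 is estimated at 4500 nM, between 1800 nM and 11000 nM.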

Compound 4, half-maximal inhibitory concentration: 3330 nM
The estimate for compound 4 lay 1.4-fold (0.13 log units) above the measured number; measured number inside the range.
By their numbers in this assay, from the lowest: compounds 4, 1, 3 and 2 (each within the scatter of the next, the first and the last beyond it).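

In this assay, within the data shown here, the change from phenyl to 4-chlorophenyl, para to a large group, now stands alone for the first time as a 1.9-fold lower number from compound 3 to compound 4 (0.27 log units; within the scatter), so chloro in place of hydrogen at this position is not resolved from the scatter. With the 4-chlorophenyl held fixed, the other arm on the saturated chain carbon gives a 1.1-fold lower number from compound 1 to compound 4 (0.04 log units; within the scatter), so 4-(tert-butyl)phenyl and 6-chloropyridin-3-yl cannot be told apart at that place. No measurement at hand bears on a cause for either step.

Open, going by these compounds, is whether another group at the chloro position, such as methoxy or an amine, would give a step beyond the scatter. Also open, on these data alone, is whether the chloro step would read the same with the plain benzyl arm of compound 2.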